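Amino-acid side-chain variation in the tail flick series

The source may report more compounds than this note shows. Statements on the series, on what has been measured and on what is new or still open speak of the compounds shown alone.

Measured so far:
compound 1 `C[C@H](NC(=O)CN(c1nc(Cl)nc2[nH]cnc12)C1CC1)C(=O)OCc1ccccc1`, 64.3% in a functional assay on the whole organism (Tail, strain ICR) with Mus musculus as the target, in the tail flick test, with a stated time of 60 min, at a dose of 25 umol/kg by the oral route; on this read-out lower numbers stand for a weaker effect and higher numbers for a stronger effect at the one dose given
compound 2 `N=C(N)NCCC[C@H](NC(=O)CN(c1nc(Cl)nc2[nH]cnc12)C1CC1)C(=O)OCc1ccccc1`, 30.6%
compound 3 `O=C(CN(c1nc(Cl)nc2[nH]cnc12)C1CC1)N[C@@H](CCC(=O)OCc1ccccc1)C(=O)OCc1ccccc1`, 53.7%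

Compound 3 stands second highest of the three: it sits a number 10.6 percentage points lower from compound 1 to compound 3 (beyond the scatter) and a number 23.1 percentage points higher from compound 2 to compound 3 (beyond the scatter). Compound 4 `CC(C)C[C@H](NC(=O)CN(c1nc(Cl)nc2[nH]cnc12)C1CC1)C(=O)OCc1ccccc1` differs from compound 3 by isopropyl in place of (benzyloxycarbonyl)methyl on a saturated chain carbon, two bonds along the chain from an amide-type nitrogen and a carbonyl carbon. Among the compounds with values here, two measured steps bear on this position. Adding the same ester-bearing group gave a number 10.6 percentage points lower from compound 1 to compound 3 (beyond the scatter), a modest loss, while adding the nitrogen-rich chain gave a number 33.7 percentage points lower from compound 1 to compound 2 (beyond the scatter), a large loss. Compound 4 carries a small alkyl group closer in kind to compound 1 than to either larger side chain, so a modest step upward is expected, a number 8.3 percentage points higher from compound 3 to compound 4 (within the scatter). Compound 4 is therefore estimated at 62%, within 46% to 78%.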

Compound 4, a percentage reported as activity, at one dose (the size of the read-out at that dose, not a potency): 27.3%
Compound 4: the middle estimate sits 34.7 percentage points above what was measured; measured number outside the range, below it.
By their numbers in this assay, from the lowest: compounds 4 and 2 (each within the scatter of the next); then compound 3; then compound 1.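

Isopropyl at this position does not behave like the hydrogen of compound 1: the data show a number 37 percentage points lower from compound 1 to compound 4 (beyond the scatter) and also a number 26.4 percentage points lower from compound 3 to compound 4 (beyond the scatter) on leaving the far larger (benzyloxycarbonyl)methyl. The carbon-only side chain and the nitrogen-rich chain of compound 2 show a number 3.3 percentage points lower from compound 2 to compound 4 (within the scatter) so side-chain size alone does not order these compounds, as compound 3 goes against any such trend. Nothing available accounts for this result.

On these data alone, a carboxylic acid in place of the benzyloxycarbonyl end of compound 3, or a simple amine on the chain, remains open.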